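From 4-fluorophenyl to 3-chlorophenyl on a shared core

This account rests on a few compounds, and the source may have more. Where it says the series, first, only, none or still open, it means among the compounds named here.

Measured so far in an ADME assay on microsomes from liver (Rattus norvegicus) for metabolic stability, read by LC-MS, in the presence of a further agent that is not named here; on this read-out higher numbers stand for fast clearance and lower numbers for slow clearance:
- compound 1 `Cc1ncc(C)n2nc(-c3ccn4cc(-c5ccccc5)nc4n3)nc12` gives 5.6 mL.min-1.g-1
- compound 2 `Cc1ncc(C)n2nc(-c3ccn4cc(-c5ccc(F)cc5)nc4n3)nc12` gives 3.1 mL.min-1.g-1

Among the measured compounds shown here, compound 2 stands within the scatter of compound 1, the only other compound measured, and the step of a 1.8-fold lower number from compound 1 to compound 2 (0.26 log units; within the scatter) is all the evidence available so far. Compound 3 `Cc1ncc(C)n2nc(-c3ccn4cc(-c5cccc(Cl)c5)nc4n3)nc12` carries 3-chlorophenyl in place of 4-fluorophenyl on an aromatic carbon of the shared core, a change counted as 3-chlorophenyl in place of 4-fluorophenyl on an aromatic carbon in full. For the measured compounds named here, the one measured step bears on this only in part, for no measured compound carries chlorine and none shows a 3-substituted phenyl. Going by the values given here, with a 1.8-fold lower number from compound 1 to compound 2 (0.26 log units; within the scatter) as the only guide, no step beyond the scatter is expected for compound 3 in this assay on this evidence. The estimated step is a 1.3-fold higher number from compound 2 to compound 3 (0.11 log units; within the scatter) and nothing larger is expected. For compound 3 the expected value is estimated at 4 mL.min-1.g-1 within an expected range from 1.8 mL.min-1.g-1 to 9 mL.min-1.g-1 overall.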

Compound 3, intrinsic clearance in microsomes: 18.9 mL.min-1.g-1
Compound 3: the middle estimate sits 4.7-fold (0.67 log units) below what was measured; the whole stated range lies below it.
By their numbers in this assay, from the lowest: compounds 2 and 1 (each within the scatter of the next); then compound 3.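

Until now, the phenyl group on this position of the shared core had shown no change beyond the scatter in this assay. Here the swap to 3-chlorophenyl gives a 6.1-fold higher number from compound 2 to compound 3 (0.79 log units; beyond the scatter), and chloro in place of hydrogen on the phenyl ring gives a 3.4-fold higher number from compound 1 to compound 3 (0.53 log units; beyond the scatter), so both steps show that a change on this phenyl ring can raise the clearance number beyond the scatter. Nothing shown accounts for the rise.

The step from compound 2 to compound 3 changes both the halogen and its place on the phenyl ring, so these compounds leave open which of the two matters more. They also leave open how this ring would behave in this assay with a nitrile, a methoxy group or an amine in place of the chlorine.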